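This account rests on a few compounds, and the source may have more. Where it says the series, first, only, none or still open, it means among the compounds named here.

Working notes on the series. In a functional assay (aorta) with Rattus norvegicus as the target (a higher number here means a weaker inhibitor, a lower number a stronger inhibitor), compound 1 (`CCCCc1cn2ccccc2c1S(=O)(=O)c1ccc(OCCCN(CCC)CCC)cc1`) gives 570 nM, compound 2 (`CCCCc1cn2ccccc2c1S(=O)(=O)c1ccc(OCCCN(CCCC)CCCC)cc1`) gives 284 nM and compound 3 (`CCN(CC)CCCOc1ccc(S(=O)(=O)c2c(C(C)C)cn3ccccc23)cc1`) gives 228 nM. Compound 2 thus lies within the scatter of both other compounds.

Compound 4 (`CCCCN(CCCC)CCCOc1ccc(S(=O)(=O)c2c(CC)cn3ccccc23)cc1`) has not yet been measured. It keeps the dibutylamino group of compound 2 and changes butyl to ethyl on the shared core, which reads as hydrogen in place of ethyl on a saturated chain carbon, two bonds along the chain from an aromatic carbon.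

For the measured compounds named here, the only measured single-place step is a 2.0-fold lower number from compound 1 to compound 2 (0.30 log units; within the scatter). It is within the scatter and concerns dibutylamino in place of dipropylamino, so it does not test the place changed here. Compound 2 also differs from compound 3 at this place and at the amino group, and compound 3 at 228 nM stays within the scatter of compound 2. That comparison is suggestive but not clean.

Going by the values given here, no measured step therefore points to a change in this assay, and no step beyond the scatter is expected. The estimated step is a 1.1-fold higher number from compound 2 to compound 4 (0.02 log units; within the scatter). The range is kept wide, since this place has no direct measurement. Compound 4 is expected at 300 nM, with an estimated range from 120 nM to 720 nM.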

Compound 4, half-maximal inhibitory concentration: 31.3 nM
Compound 4: the middle estimate sits 9.6-fold (0.98 log units) above what was measured; measured number outside the range, below it.
By their numbers in this assay, from the lowest: compound 4; then compounds 3, 2 and 1 (each within the scatter of the next, the first and the last beyond it).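

In this assay, for the compounds shown here, the step from butyl to ethyl on the shared core, a 9.1-fold lower number from compound 2 to compound 4 (0.96 log units; beyond the scatter), is the first single-place step to lie beyond the scatter, so this place affects the number in a way the earlier compounds could not show. The dibutylamino for dipropylamino step, a 2.0-fold lower number from compound 1 to compound 2 (0.30 log units; within the scatter), stays within the scatter, and among the single-place steps at hand only the change of hydrogen in place of ethyl on a saturated chain carbon, two bonds along the chain from an aromatic carbon, separates two compounds clearly. No measurement at hand bears on the reason for this step.

The shown compounds rest on one pair at this place, so it stays open whether a methyl group or a propyl chain there would follow the same direction, and whether the number keeps falling as the chain shortens. As far as these compounds go, it also stays open whether butyl to ethyl gives a step of the same size when the amine carries dipropylamino rather than dibutylamino.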